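The source may report more compounds than this note shows. Statements on the series, on what has been measured and on what is new or still open speak of the compounds shown alone.

Measured in a functional assay on OVCAR-3 cells (Homo sapiens) for cytotoxicity, read by sulforhodamine B assay; a higher number here means that more compound is tolerated, a lower number that less compound is tolerated:

Compound 1 `CC1=CC[C@@H]([C@@](C)(O)CCCC(C)(C)NC(=S)N/N=C\c2ccccc2)CC1`: 43600 nM
Compound 2 `CC1=CC[C@@H]([C@@](C)(O)CCCC(C)(C)NC(=S)N/N=C\c2ccc(C)cc2)CC1`: 45300 nM
Compound 3 `CC1=CC[C@@H]([C@@](C)(O)CCCC(C)(C)NC(=S)N/N=C\c2ccc(N(C)C)cc2)CC1`: > 100000 nM, a limit of the assay

Compound 1, at 43600 nM, stands level with compound 2, at 45300 nM, the two values lying within the scatter of each other. Compound 3 gives > 100000 nM, and this is a limit, not a number.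

Compound 4 `CC1=CC[C@@H]([C@@](C)(O)CCCC(C)(C)NC(=S)N/N=C\c2ccccc2[N+](=O)[O-])CC1` is compound 1 with phenyl changed to 2-nitrophenyl: nitro in place of hydrogen on an aromatic carbon. The nitro group sits on an aromatic carbon, ortho to a large group.

For the measured compounds named here, two measured steps bear on this change, though neither introduces nitro. Methyl gave a 1.0-fold higher number from compound 1 to compound 2 (0.02 log units; within the scatter). Dimethylamino gave an at least 2.2-fold higher number from compound 1 to compound 3 (0.36 log units; beyond the scatter). On these data alone, with one step within the scatter and the other only modest, a large step is not expected in this assay, and the direction remains open. The estimated result is a 1.0-fold lower number from compound 1 to compound 4 (0.02 log units; within the scatter). For compound 4 the expected value is 42000 nM, with an estimated range of 15000 nM to 100000 nM.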

Compound 4, concentration lethal to 50% of the cells: 41900 nM
Estimate against measurement, compound 4: 1.0-fold (0.00 log units) above; measured number inside the range.
By their numbers in this assay, from the lowest: compounds 4, 1 and 2 (each within the scatter of the next). At a limit, above all of these: compound 3.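

In this assay, compound 4 is the only one shown with a group ortho to a large group, and nitro there leaves the number level: a 1.0-fold lower number from compound 1 to compound 4 (0.02 log units; within the scatter), and a 1.1-fold lower number from compound 2 to compound 4 (0.03 log units; within the scatter). Only the dimethylamino compound stands apart from this group of values, with an at least 2.3-fold lower number from compound 3 to compound 4 (0.37 log units; beyond the scatter). Compound 3 remains a limit and not a number, so the full size of that gap cannot be read: the limit of > 100000 nM in this assay, at which 1 of the 4 values shown sits.

The compounds shown leave open whether dimethylamino, or a carboxylic acid, would leave the number level when placed ortho to a large group, as nitro does. They also leave open whether nitro would behave the same way at another aromatic carbon of this ring, and whether a primary amine in its place would give a similar value.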